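Aryl swap on the triazole nitrogen of the spiro series

This account rests on a few compounds, and the source may have more. Where it says the series, first, only, none or still open, it means among the compounds named here.

Compound 1 `N#CC1=C(N)Oc2c(c3nc4ccccc4nc3c3ccccc23)C12C(=O)N(Cc1cnnn1-c1ccccc1Br)c1ccccc12` stands in a functional assay on MCF7 cells (Homo sapiens) for antiproliferative activity, read by MTT assay, with a stated time of 48 h (on this read-out higher numbers stand for weaker inhibition and lower numbers for stronger inhibition), only at a limit: compound 1 gives > 50000 nM, which is a limit of the assay and not a number. Compound 2 `CCOc1ccccc1-n1nncc1CN1C(=O)C2(C(C#N)=C(N)Oc3c2c2nc4ccccc4nc2c2ccccc32)c2ccccc21` likewise reaches only a limit there, as compound 2 gives > 50000 nM. Going by the values given here, the single measured step, a step that the two limits leave unreadable from compound 1 to compound 2, therefore has no readable size, and both values of the pair sit at the limit of > 50000 nM in this assay, at which 2 of the 2 values shown sit.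

Compound 3 `CC(=O)Nc1ccc(-n2nncc2CN2C(=O)C3(C(C#N)=C(N)Oc4c3c3nc5ccccc5nc3c3ccccc43)c3ccccc32)cc1` differs from compound 1 by 4-acetamidophenyl in place of 2-bromophenyl on an aromatic nitrogen. Among the compounds with values here, no measured step touches this position with a readable size, and the one step that was measured left both of its ends at the limit. The shown numbers give no direction for the change to compound 3, so the step of a number no higher from compound 1 to compound 3 (the limit leaves the size open) is expected to be none beyond the scatter. Compound 3 is estimated at 50000 nM, with a range from 20000 nM to 150000 nM, and the most likely outcome is that the assay again reports only a limit rather than a number.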

Compound 3, half-maximal inhibitory concentration: > 50000 nM
Compound 3 gave a limit, no number; the forecaster's own chance of this, stated with the estimate: 85%; the middle value lies on the limit itself.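

In this assay compound 3 gives > 50000 nM, which is a limit of the assay and not a number. No new step can be read, since the steps linking compound 3 with compound 1 and compound 2 join limits only: the limit of > 50000 nM in this assay, at which 3 of the 3 values shown sit.

The compounds shown leave open whether any aryl group on the aromatic nitrogen gives a measurable value in this assay.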